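Removing the tert-butylphenyl group: an expected loss of potency

The source may hold more compounds than are shown below. What is called first, only, known or untested is meant among the compounds shown, and "the series" means these compounds.

Measured compounds:
- compound 1, `COC(=O)/C=C/c1cccc(N(Cc2ccc(/C=C/c3ccccc3F)cc2)C(=O)C2CCCCC2)c1`: 64 nM
- compound 2, `COC(=O)/C=C/c1cccc(N(Cc2ccc(-c3ccc(C(C)(C)C)cc3)cc2)C(=O)C2CCCCC2)c1`: 132 nM

Both compounds share one core and differ only in the group attached to the benzyl ring. In an assay on isolated protein with Bile acid receptor (Homo sapiens) as the target (on this read-out higher numbers stand for an effect only at larger amounts of compound and lower numbers for an effect already at smaller amounts), compound 1 gives 64 nM and compound 2 gives 132 nM. Compound 2 therefore stands at the higher of the two numbers, and the step of a 2.1-fold higher number from compound 1 to compound 2 (0.31 log units; beyond the scatter) is modest but beyond the scatter.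

Compound 3, `COC(=O)/C=C/c1cccc(N(Cc2ccccc2)C(=O)C2CCCCC2)c1`, has not yet been measured. It differs from compound 2 by hydrogen in place of 4-(tert-butyl)phenyl on an aromatic carbon; in other words, the whole aromatic ring together with its tert-butyl group is cut away, leaving only a plain benzyl group on the nitrogen.

Within the data shown here, the one measured step, from compound 1 to compound 2, only swaps one group for another of similar size and says little about removing the group altogether. Among the measured compounds shown here, no measured pair shows such a deletion. With that caution, a clear weakening is expected, so the step of an 11-fold higher number from compound 2 to compound 3 (1.06 log units; beyond the scatter) is estimated in the direction of higher numbers. Compound 3 is estimated at 1500 nM, with a range from 300 nM to 8000 nM.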

Compound 3, half-maximal effective concentration: > 1000 nM
Compound 3 was reported as a limit; the forecaster's own chance of this, stated with the estimate: 20%; the middle value is on the limit's open side.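

Compound 3 is reported in this assay only as a limit, not as a number: the limit of > 1000 nM in this assay, at which 1 of the 3 values shown sits. Among these compounds, replacing the 4-(tert-butyl)phenyl group with hydrogen gives an at least 7.5-fold higher number from compound 2 to compound 3 (0.87 log units; beyond the scatter), and replacing the 2-(2-fluorophenyl)ethenyl group with hydrogen gives an at least 15-fold higher number from compound 1 to compound 3 (1.19 log units; beyond the scatter), so this is the first view of what happens when the aromatic carbon carries no large group at all. Swapping one large group for the other gave only a 2.1-fold higher number from compound 1 to compound 2 (0.31 log units; beyond the scatter), so among these three compounds, having a large group at this place matters more than which of the two large groups it is.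

The compounds shown leave open how much of a group this place needs, for instance whether a single methyl, a chlorine atom or a plain phenyl ring would keep the number close to those of the two larger groups or leave it near that of the bare benzyl group. On these data alone, the full size of both deletion steps also stays open, as does the effect of any of these changes on a version of the shared core that carries a carboxylic acid in place of the methyl ester.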